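Chloro-to-amino swap on the fused core, single-concentration readout

The compounds below may be only part of what the source reports. "The series", "measured", "known", "first", "only" and "open" are said of these compounds alone.

Measured compounds:
compound 1 `Clc1ncnc2ncn(Cc3ccccc3)c12`: 0%
compound 2 `Fc1ccc(Cn2cnc3ncnc(Cl)c32)cc1`: 0%

In an assay on isolated protein for inhibition of RAC-alpha serine/threonine-protein kinase (Homo sapiens), tested at 30 uM (on this read-out higher numbers stand for more inhibition at the one concentration tested (going by the name of the read-out) and lower numbers for less inhibition), compound 1 gives 0% and compound 2 gives 0%. Within the data shown here, the one measured step, fluoro in place of hydrogen on an aromatic carbon, is no change at the digits printed from compound 1 to compound 2 (within the scatter). Compound 2 therefore stands level with compound 1 at the digits shown, both at the bottom of the scale, with nothing in the series so far rising above the scatter.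

Compound 3 `Nc1ncnc2ncn(Cc3ccc(F)cc3)c12` is not yet measured in this assay. It differs from compound 2 by amino in place of chloro on an aromatic carbon. Among the measured compounds shown here, no measured step touches this part of the shared core, so the only guide is that both measured compounds sit at the floor in this assay. The step from compound 2 is expected to be a number 5 percentage points higher from compound 2 to compound 3 (within the scatter), a change not clearly beyond the scatter. Compound 3 is estimated at 5%, with a range from 0% to 25%.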

Compound 3, a percentage reported as inhibition, at one concentration (the size of the read-out at that concentration, not a potency): 0%
Beside the measured number, compound 3's estimate is 5 percentage points above it; the measured number falls inside the stated range.
By their numbers in this assay, from the lowest: compounds 1, 2 and 3 (each within the scatter of the next).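

In this assay, amino in place of chloro on an aromatic carbon of the six-membered aromatic ring with 2 nitrogen reads as no change at the digits printed from compound 2 to compound 3 (within the scatter). Among these compounds, this is the only step so far that changes this position on the shared core, and it shows that exchanging chloro for amino, with the hydrogen-bond donor and acceptor that amino adds, does not lift compound 3 off the floor of the read-out. No supporting data bear on why this exchange leaves the value at the floor.

Going by these compounds, whether a larger group at this position, such as a morpholine or an amine carrying a longer chain, would give measurable inhibition remains open. With every value at the floor, the series also cannot show whether chloro, amino or fluoro has any influence at all.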